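Swapping the aryl group on the shared core

The source may hold more compounds than are shown below. What is called first, only, known or untested is meant among the compounds shown, and "the series" means these compounds.

Of the compounds shown here, three with one shared core have been measured in a functional assay on MCF7 cells (Homo sapiens) for inhibition, read by sulforhodamine B assay; a lower number here means a stronger inhibitor, a higher number a weaker inhibitor. Compound 1 `CCCc1ccc(NC2=CC(=O)c3nc4n(c3C2=O)[C@H]2OC[C@@H](O)[C@H]2OC4)cc1` gives 4660 nM, compound 2 `COc1ccccc1NC1=CC(=O)c2c(nc3n2[C@H]2OC[C@@H](O)[C@H]2OC3)C1=O` gives 6580 nM, and compound 3 `Cc1ccc(NC2=CC(=O)c3nc4n(c3C2=O)[C@H]2OC[C@@H](O)[C@H]2OC4)cc1C` gives 2080 nM. Compound 2 shows the highest number of the three; its gap to compound 1 lies within the scatter, its gap to compound 3 beyond it. For the measured compounds named here, the only step between measured compounds is a 2.2-fold lower number from compound 1 to compound 3 (0.35 log units; beyond the scatter), a change of the group on the amine nitrogen. Compound 4 `O=C1C(Nc2cccc(Cl)c2)=CC(=O)c2c1nc1n2[C@H]2OC[C@@H](O)[C@H]2OC1` differs from compound 2 as follows: 3-chlorophenyl in place of 2-methoxyphenyl on an amine nitrogen. Going by the values given here, no measured step involves either of these groups, so the one aryl swap, which was modest, is the only guide. The number for compound 4 is therefore expected near 4000 nM, between 1500 nM and 9000 nM. The expected step is a 1.6-fold lower number from compound 2 to compound 4 (0.22 log units; within the scatter).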

Compound 4, half-maximal inhibitory concentration: 2970 nM
Estimate against measurement, compound 4: 1.3-fold (0.13 log units) above, within the range that was stated.
By their numbers in this assay, from the lowest: compounds 3, 4, 1 and 2 (each within the scatter of the next, the first and the last beyond it).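

In this assay the swap on the amine nitrogen gives a 2.2-fold lower number from compound 2 to compound 4 (0.35 log units; beyond the scatter) and so shows that this position accepts a chlorine-bearing ring, with the hydrogen-bond acceptor of the 2-methoxyphenyl group gone and no rise in the number. Because both the substituent and its place on the ring change in this one step, the two contributions cannot be separated, and no measurement here accounts for the step. Still open, going by these compounds, is how 3-methoxyphenyl or 2-chlorophenyl would read, and whether an amine or carboxylic acid on the ring would be accepted.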